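A few compounds are considered here, and "the series" means these few. Any claim that something is new, unique, unknown or untested is made for them only; others in the source may bear on it.

Compound 1, `CN(C)/C=N/c1c(C=O)c(-c2ccccc2)nn1-c1ccccc1` — 23500 nM
Compound 2, `Cc1ccc(-c2nn(-c3cccc(Cl)c3)c(/N=C/N(C)C)c2C=O)cc1` — 7800 nM
Compound 3, `CN(C)/C=N/c1cc(-c2ccccc2)nn1-c1ccccc1` — > 100000 nM

In a functional assay on Jurkat cells (Homo sapiens) for inhibition, read by MTT assay, with a stated time of 72 h (on this read-out lower numbers stand for stronger inhibition of growth and higher numbers for weaker inhibition of growth), compound 1 gives 23500 nM and compound 2 gives 7800 nM, a lower number that lies beyond the usual scatter. For compound 3 only a limit of this assay is reported, > 100000 nM. The change from compound 1 to compound 3 is hydrogen in place of formyl on an aromatic carbon; it produced an at least 4.2-fold higher number from compound 1 to compound 3 (0.62 log units; beyond the scatter), with compound 3 sitting at the limit of > 100000 nM in this assay, at which 1 of the 3 values shown sits.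

The same kind of change leads from compound 2 to compound 4, `Cc1ccc(-c2cc(/N=C/N(C)C)n(-c3cccc(Cl)c3)n2)cc1`: hydrogen in place of formyl on an aromatic carbon. The place differs in its surroundings: in compound 2 the carbon is next to the ring atom that bears a 4-methylphenyl group and two ring bonds from the ring atom that bears a 3-chlorophenyl group, whereas in compound 1 both of those ring atoms bear a phenyl group. The difference between the cores of compound 1 and compound 2 is not broken down here.

Because the formyl removal in compound 1 gave an at least 4.2-fold higher number from compound 1 to compound 3 (0.62 log units; beyond the scatter), a comparable loss is expected for compound 4, a 7.7-fold higher number from compound 2 to compound 4 (0.89 log units; beyond the scatter). Compound 4 is therefore estimated at 60000 nM, expected between 20000 nM and 120000 nM, possibly ending as a limit in this assay.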

Compound 4, concentration for 50% growth inhibition: > 100000 nM
Compound 4: only a limit was reported; the forecaster's own chance of this, stated with the estimate: 45%; middle value at least 1.6-fold (0.22 log units) from the limit.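

Carried to the core of compound 2, the replacement of formyl by hydrogen gave an at least 12-fold higher number from compound 2 to compound 4 (1.10 log units; beyond the scatter) in this assay, so on both cores shown the compound bearing hydrogen has the higher number. Compound 4 is reported only as a limit of the assay, > 100000 nM, so this step marks a lower bound and not a measured size. The direction of the change therefore carries over between these two cores, but whether its size carries over cannot be told: the same change on two cores in this assay, an at least 4.2-fold higher number (0.62 log units; beyond the scatter) from compound 1 to compound 3 and an at least 12-fold higher number (1.10 log units; beyond the scatter) from compound 2 to compound 4; the limit leaves it open whether they differ.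

The compounds shown leave open whether a different group on that aromatic carbon, such as a carboxylic acid, a nitrile or a hydroxymethyl group, would keep the lower numbers seen with formyl. They also leave open what the 4-methylphenyl group and the 3-chlorophenyl group each contribute alone, and whether the same change would carry over to a core with other groups on its ring.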